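The source may hold more compounds than are shown below. What is called first, only, known or untested is meant among the compounds shown, and "the series" means these compounds.

Measured so far in an ADME assay on microsomes from liver (Homo sapiens) for metabolic stability, tested at 2.5 uM; on this read-out higher numbers stand for fast clearance and lower numbers for slow clearance:
- compound 1 `O=S(=O)(c1ccc(F)cc1)c1cnc2cc(F)ccc2c1-c1cccc(F)c1`, 0.95 mL/min
- compound 2 `O=S(=O)(c1ccc(F)cc1)c1cnc2cc(F)ccc2c1-c1ccc(F)cc1`, 1.34 mL/min
- compound 3 `COc1ccc(-c2c(S(=O)(=O)c3ccc(F)cc3)cnc3c(F)cccc23)cc1`, 2.41 mL/min

Of these three numbers, compound 1 carries the smallest, yet its gap to compound 2 is within the scatter, so the two cannot be told apart; only compound 3 lies beyond the scatter from compound 1. Among the measured compounds shown here, the single step between measured compounds that differ in one place, a swap of fluorophenyl groups on an aromatic carbon, gave a 1.4-fold higher number from compound 1 to compound 2 (0.15 log units; within the scatter).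

Compound 4 `O=S(=O)(c1cccc(F)c1)c1cnc2cc(F)ccc2c1-c1cccc(F)c1` differs from compound 1 by 3-fluorophenyl in place of 4-fluorophenyl on a sulfonyl sulfur. For the measured compounds named here, no measured pair shows a change at a sulfonyl sulfur, so the step to compound 4 has no direct precedent. The closest guide is the swap of the same two groups at another position, which moved the number only within the scatter. The expectation is therefore for no change beyond the scatter in this assay, with an estimated step of a 1.2-fold higher number from compound 1 to compound 4 (0.06 log units; within the scatter). Compound 4 is expected to give 1.1 mL/min, in a range from 0.55 mL/min to 2.2 mL/min.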

Compound 4, intrinsic clearance in a liver preparation (reported as CLH), per the amount of preparation that the assay uses: 0.24 mL/min
The estimate for compound 4 lay 4.6-fold (0.66 log units) above the measured number; the whole stated range lies above it.
By their numbers in this assay, from the lowest: compound 4; then compounds 1, 2 and 3 (each within the scatter of the next, the first and the last beyond it).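

In this assay, the sulfonyl sulfur proves to be a place where the choice between these two groups counts: 3-fluorophenyl in place of 4-fluorophenyl there gives a clear drop, toward slower clearance (a 4.0-fold lower number from compound 1 to compound 4 (0.60 log units; beyond the scatter)). The same two groups exchanged the other way round on an aromatic carbon gave a step within the scatter (a 1.4-fold higher number from compound 1 to compound 2 (0.15 log units; within the scatter)), so the result at one place did not carry over to the other. Nothing at hand gives a reason for the drop.

On these data alone, the change at the sulfonyl sulfur is seen only once, on the core of compound 1, so it is open whether it would hold with other groups on that core. Also open, as far as these compounds go, is how a plain phenyl, a pyridine or an amine would behave on the sulfonyl sulfur.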